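Amide nitrogen substituents on a shared dimethoxy core

The compounds below may be only part of what the source reports. "The series", "measured", "known", "first", "only" and "open" are said of these compounds alone.

Measured in a functional assay on the whole organism (strain Wistar) for inhibition, with Rattus norvegicus as the target, read by paw edema, with stated times of 60 min and 4 h, at a dose of 100 mg/kg by the oral route; on this read-out higher numbers stand for more inhibition at the one dose given (going by the name of the read-out) and lower numbers for less inhibition:
compound 1 `COc1cc2c(cc1OC)C(CC(N)=O)CC2` — 31.3%
compound 2 `COc1cc2c(cc1OC)C(CC(=O)NC(C)C)CC2` — 39.1%

Two compounds have been run so far, and they differ only at the amide-type nitrogen. Going by the values given here, compound 2 holds the larger of the two numbers in this assay, but the one step leading to it, a number 7.8 percentage points higher from compound 1 to compound 2 (within the scatter), lies within the scatter, so the two compounds cannot be separated on these data.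

Compound 3 `CCCCCCNC(=O)CC1CCc2cc(OC)c(OC)cc21` is the next member to be measured in this assay. Relative to compound 2 the change is hexyl in place of isopropyl on an amide-type nitrogen. Among the compounds with values here, the only measured step bearing on this position is a number 7.8 percentage points higher from compound 1 to compound 2 (within the scatter), where a larger group entering on the same nitrogen produced no movement beyond the scatter. With one step of that kind and nothing else to go on, a further change of the chain on the amide-type nitrogen is expected to give a step of about a number 0.9 percentage points higher from compound 2 to compound 3 (within the scatter), that is, none beyond the scatter, in this assay.

Compound 3 is therefore estimated at 40% in this assay, within a range from 24% to 56%.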

Compound 3, a percentage reported as inhibition, in the whole organism at one dose (the size of the read-out at that dose, not a potency): 42.1%
Compound 3: middle estimate off by 2.1 percentage points, on the low side; the range from low to high includes it.
By their numbers in this assay, from the lowest: compounds 1, 2 and 3 (each within the scatter of the next, the first and the last beyond it).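

In this assay, hexyl in place of isopropyl on the amide-type nitrogen gives a number 3 percentage points higher from compound 2 to compound 3 (within the scatter), so these two chains cannot be separated on the present data. Going by these compounds alone, the new information lies in the comparison with the unsubstituted amide: hexyl in place of hydrogen on the same nitrogen gives a number 10.8 percentage points higher from compound 1 to compound 3 (beyond the scatter), the first step at this position to lie beyond the scatter, though only modestly. Compound 2 remains within the scatter of both compound 1 and compound 3, so the series supports a modest difference between its two end members but no graded order along the three, and nothing available accounts for either step.

Still open, going by these compounds, is whether a longer chain than hexyl on this nitrogen would move the number further from that of compound 1 or leave it within the scatter of compound 3. Also open is how a ring such as cyclohexyl, or a hexyl chain ending in an amine or a carboxylic acid, would read at this position, since all the substituents shown are plain open carbon chains.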